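The source may hold more compounds than are shown below. What is called first, only, known or untested is meant among the compounds shown, and "the series" means these compounds.

Measured so far in an assay on isolated protein for inhibition of Dihydrofolate reductase (Homo sapiens), read by spectrophotometry, with a stated time of 5 min; a lower number here means a stronger inhibitor, a higher number a weaker inhibitor:

- compound 1, `CC(=O)C1=C(C)NC(=S)NC1c1cccc(O)c1`: 9400 nM
- compound 2, `CCOC(=O)C1=C(C)NC(=S)NC1c1ccccc1OC`: 1900 nM
- compound 3, `CC(=O)C1=C(C)N=C(SCCC(=O)O)NC1c1ccccc1`: 1.3 nM

Compound 3 sits at the lowest number of the three. Its nearest neighbour by value is compound 2, whose number is far higher, beyond the scatter; compound 1 stands further off still. Compound 3 is thus the strongest inhibitor among the measured set in this assay. Among the compounds with values here, no two measured compounds differ in only one place, so no single step can be read off between them; compound 1 and compound 2 differ from compound 3 at the core and at the aryl ring at once, and their values say only that both combinations land much higher.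

Compound 4, `CC(=O)C1=C(C)N=C(SCCC(=O)O)NC1c1cccc(O)c1`, has not yet been measured. The change from compound 3 is hydroxy in place of hydrogen on an aromatic carbon, the entering group placed on an aromatic carbon of a six-membered aromatic ring of carbon only, meta to a large group. Compound 1 carries the same hydroxy on its ring, but on a different core, so it gives no guide to the size of this step. Nothing here points to a shift beyond the scatter in either direction; a small step is expected.

For compound 4 the expected value in this assay is 2 nM, with a range of 0.5 nM to 10 nM, corresponding to an expected step of a 1.5-fold higher number from compound 3 to compound 4 (0.19 log units; within the scatter).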

Compound 4, half-maximal inhibitory concentration: 94 nM
Compound 4: the middle estimate sits 47-fold (1.67 log units) below what was measured; the measured number lies above the stated range.
By their numbers in this assay, from the lowest: compound 3; then compound 4; then compound 2; then compound 1.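

In this assay hydroxy in place of hydrogen on an aromatic carbon, meta to a large group, gives a 72-fold higher number from compound 3 to compound 4 (1.86 log units; beyond the scatter) and so shows that this place on the ring shared by compound 3 and compound 4 is sensitive to even a single added heavy atom. Within the data shown here, the earlier compounds offered no single step, and the hydroxy of compound 1 sat on a different core, so this pair gives the first direct reading of what the group does. Nothing at hand accounts for the size of the step.

Going by these compounds, whether the loss is specific to hydroxy or follows any group at this place remains open: methoxy, fluorine or an amine on the same carbon would separate these cases, as would hydroxy on another carbon of the ring. Also open, on these data alone, is whether a step of this size holds with an ethyl ester in place of the acetyl group, or with a longer chain carrying the carboxylic acid.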